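Cyclohexyl in Place of tert-Butyl on the Methylated Amide

The source may hold more compounds than are shown below. What is called first, only, known or untested is meant among the compounds shown, and "the series" means these compounds.

Of the compounds shown here, three sharing one core have been measured in an assay on HeLa cells for displacement of a labelled ligand from adenosine receptor A3 (Homo sapiens), read by fluorescence polarization, with a stated time of 30 min; on this read-out higher numbers stand for weaker inhibition and lower numbers for stronger inhibition. Compound 1 `COc1ccc(-c2cc(NC(=O)COCC(=O)NCC(=O)NC(C)(C)C)nc(-c3ccc(OC)cc3)n2)cc1` gives 11200 nM, compound 2 `COc1ccc(-c2cc(NC(=O)COCC(=O)NCC(=O)NC3CCCCC3)nc(-c3ccc(OC)cc3)n2)cc1` gives 14000 nM, and compound 3 `COc1ccc(-c2cc(NC(=O)COCC(=O)N(C)CC(=O)NC(C)(C)C)nc(-c3ccc(OC)cc3)n2)cc1` gives 7200 nM. Compound 3 thus holds the lowest of the three numbers, yet the steps of a 1.6-fold lower number from compound 1 to compound 3 (0.19 log units; within the scatter) and a 1.9-fold lower number from compound 2 to compound 3 (0.29 log units; within the scatter) are both within the scatter, so no ordering among the three can be claimed.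

Compound 4 `COc1ccc(-c2cc(NC(=O)COCC(=O)N(C)CC(=O)NC3CCCCC3)nc(-c3ccc(OC)cc3)n2)cc1` is not yet measured. It differs from compound 3 by cyclohexyl in place of tert-butyl on an amide-type nitrogen. The same exchange has already been seen once, without the methyl on the adjoining amide nitrogen: a 1.3-fold higher number from compound 1 to compound 2 (0.10 log units; within the scatter), a step that stayed within the scatter. On that basis only a small move is expected for compound 4 in this assay. The expected step of a 1.3-fold higher number from compound 3 to compound 4 (0.10 log units; within the scatter) is in the same direction as that earlier exchange, though it may well be nothing beyond the scatter. Compound 4 is therefore estimated at 9000 nM, with a range from 4000 nM to 20000 nM.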

Compound 4, inhibition constant: 10100 nM
Compound 4: middle estimate off by 1.1-fold (0.05 log units), on the low side; low and high end bracket the measured number.
By their numbers in this assay, from the lowest: compounds 3, 4, 1 and 2 (each within the scatter of the next).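

With compound 4, cyclohexyl in place of tert-butyl on an amide-type nitrogen can be read a second time in this assay, now with the methyl present, as a 1.4-fold higher number from compound 3 to compound 4 (0.15 log units; within the scatter), and the two readings agree: the same change on two cores in this assay, a 1.3-fold higher number (0.10 log units; within the scatter) from compound 1 to compound 2 and a 1.4-fold higher number (0.15 log units; within the scatter) from compound 3 to compound 4, 1.1-fold (0.05 log units) apart, within the scatter of two such steps

Methyl in place of hydrogen on an amide-type nitrogen, so far read only with tert-butyl, can now also be read with cyclohexyl, as a 1.4-fold lower number from compound 2 to compound 4 (0.14 log units; within the scatter), and these readings agree as well: the same change on two cores in this assay, a 1.6-fold lower number (0.19 log units; within the scatter) from compound 1 to compound 3 and a 1.4-fold lower number (0.14 log units; within the scatter) from compound 2 to compound 4, 1.1-fold (0.05 log units) apart, within the scatter of two such steps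

With both changes taken together, as a 1.1-fold lower number from compound 1 to compound 4 (0.04 log units; within the scatter), the step also stays within the scatter, so across these four compounds neither change takes the number beyond it.

On these data alone, what remains open is whether a phenyl, a benzyl or an amine-bearing group in place of cyclohexyl would move the number beyond the scatter. The same holds for an ethyl or a longer chain in place of the methyl.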